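The compounds below may be only part of what the source reports. "The series", "measured", "known", "first", "only" and "open" are said of these compounds alone.

In an assay on isolated protein for displacement of a labelled ligand from metabotropic glutamate receptor 5 (Homo sapiens), with a stated time of 60 min, tested at 1 uM (on this read-out lower numbers stand for less inhibition and higher numbers for more inhibition at the one concentration tested (going by the name of the read-out)), compound 1 `CC1CCN(c2c(S(=O)(=O)c3ccccc3)cnc3ccc(F)cc23)CC1` gives 40%, compound 2 `Cc1ccc2ncc(S(=O)(=O)c3ccccc3)c(N3CCC(C)CC3)c2c1` gives 67% and compound 3 `CC1CCN(c2c(S(=O)(=O)c3ccccc3)cnc3ccc(Cl)cc23)CC1` gives 59%. On the numbers, compound 2 sits highest of the three, but its gap to compound 3, a number 8 percentage points lower from compound 2 to compound 3 (within the scatter), lies within the scatter, so these two are not separated; the gap from compound 1 is a number 27 percentage points higher from compound 1 to compound 2 (beyond the scatter), and likewise a number 19 percentage points higher from compound 1 to compound 3 (beyond the scatter) runs beyond the scatter. Compound 4 `COc1ccc(S(=O)(=O)c2cnc3ccc(C)cc3c2N2CCC(C)CC2)cc1Cl` differs from compound 2 by 3-chloro-4-methoxyphenyl in place of phenyl on a sulfonyl sulfur. Among the compounds with values here, all three measured steps concern the substituent on an aromatic carbon of the shared core; none touches the group on the sulfonyl sulfur, so no measured step bears on this change, and no step beyond the scatter is expected. Compound 4 is therefore estimated at 65% in this assay, range 40% to 85%, meaning an expected step of a number 2 percentage points lower from compound 2 to compound 4 (within the scatter).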

Compound 4, a percentage reported as inhibition, at one concentration (the size of the read-out at that concentration, not a potency): 93%
Compound 4: middle estimate off by 28 percentage points, on the low side; the measured number lies above the stated range.
By their numbers in this assay, from the lowest: compound 1; then compounds 3 and 2 (each within the scatter of the next); then compound 4.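

The group on the sulfonyl sulfur is a responsive position in this assay: 3-chloro-4-methoxyphenyl in place of phenyl gives a number 26 percentage points higher from compound 2 to compound 4 (beyond the scatter). Within the data shown here, this is the first step seen at this place, and it shows that the read-out moves with changes at the sulfonyl sulfur as well as on the aromatic carbon of the shared core. Nothing at hand bears on what lies behind this step.

The compounds shown do not separate the chloro from the methoxy part of the new group. Also open, as far as these compounds go, is how a 4-aminophenyl or a pyridine ring would read on the sulfonyl sulfur, and whether the step carries over to the fluoro and chloro cores of compound 1 and compound 3.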